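Aryl Swap on the Amide and Agonist Efficacy

A few compounds are considered here, and "the series" means these few. Any claim that something is new, unique, unknown or untested is made for them only; others in the source may bear on it.

Compound 1 `C=Cc1cccc(C(=O)NCN2CCC(c3cccc[n+]3[O-])CC2)c1`: 63%
Compound 2 `O=C(NCN1CCC(c2cccc[n+]2[O-])CC1)c1cc(Cl)cc(Cl)c1`: 64%

In a functional assay on HEK293 cells for agonist activity at D(4) dopamine receptor (Homo sapiens), read by FLIPR (on this read-out higher numbers stand for larger maximal responses and lower numbers for smaller maximal responses), compound 1 gives 63% and compound 2 gives 64%. Among the measured compounds shown here, compound 2 stands level with compound 1: the single measured step, a number 1 percentage points higher from compound 1 to compound 2 (within the scatter), lies within the scatter, so the two numbers cannot be told apart.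

Compound 3 `O=C(NCN1CCC(c2cccc[n+]2[O-])CC1)c1ccccn1` has not yet been measured. It differs from compound 2 as follows: pyridin-2-yl in place of 3,5-dichlorophenyl on a carbonyl carbon. For the measured compounds named here, the one step already measured, a number 1 percentage points higher from compound 1 to compound 2 (within the scatter), concerns an exchange of the aryl group on the same carbonyl carbon and did not move the maximal response beyond the scatter. Going by the values given here, with only that step to go on, compound 3 is expected to show a change of about a number 2 percentage points lower from compound 2 to compound 3 (within the scatter) in this assay, that is, none beyond the scatter. Compound 3 is therefore estimated at 62%, within a range from 42% to 82%.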

Compound 3, largest response reached (reported as efficacy), in percent of the reference or control that the assay uses: 40%
Estimate against measurement, compound 3: 22 percentage points above; measured number outside the range, below it.
By their numbers in this assay, from the lowest: compound 3; then compounds 1 and 2 (each within the scatter of the next).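

The aryl group on the carbonyl carbon is not an indifferent place in this assay: pyridin-2-yl brings a number 24 percentage points lower from compound 2 to compound 3 (beyond the scatter) and a number 23 percentage points lower from compound 1 to compound 3 (beyond the scatter), while compound 1 and compound 2, which both carry a ring of carbon only with different substituents, stand level. Among these three compounds, the one lower maximal response goes with the one ring that holds a hetero atom and a hydrogen-bond acceptor, though compound 3 also carries no substituent on that ring. Nothing measured here accounts for the lower response.

The compounds shown do not separate the ring nitrogen from the loss of the substituents, a question that unsubstituted phenyl on the same carbonyl carbon would address. As far as these compounds go, it also remains open whether pyridin-3-yl or pyridin-4-yl would give the same maximal response as pyridin-2-yl.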